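Removing the ring halogen of compound 2

A few compounds are considered here, and "the series" means these few. Any claim that something is new, unique, unknown or untested is made for them only; others in the source may bear on it.

Within the data shown here, compound 2 `Cc1cc(C(=O)O)nn1Cc1cc(Cl)ccc1OCc1ccc(Cl)cc1Cl` sits second highest of the three numbers so far in a functional assay on CHO-K1 cells for antagonist activity at prostaglandin E2 receptor EP1 subtype (Homo sapiens), read by FLIPR (a higher number here means a weaker inhibitor, a lower number a stronger inhibitor), giving 0.55 nM. Its nearest neighbour is compound 1 `Cc1cc(C(=O)O)nn1Cc1cc(Br)ccc1OCc1ccc(Cl)cc1Cl`, which gives 0.49 nM; the difference a 1.1-fold higher number from compound 1 to compound 2 (0.05 log units; within the scatter) is within the scatter. The furthest is compound 3 `Cc1cc(C(=O)O)nn1Cc1cc(Cl)ccc1OCc1ccc(F)cc1F`, which gives 1.12 nM; the step of a 2.0-fold higher number from compound 2 to compound 3 (0.31 log units; beyond the scatter) is modest but beyond the scatter.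

Compound 4 `Cc1cc(C(=O)O)nn1Cc1ccccc1OCc1ccc(Cl)cc1Cl` is the next point. The change is hydrogen in place of chloro on an aromatic carbon: the chloro leaves, a hydrogen enters, on an aromatic carbon of a six-membered aromatic ring of carbon only, meta to a large group and para to a large group. Of the measured steps, only a 1.1-fold higher number from compound 1 to compound 2 (0.05 log units; within the scatter) touches this position, and swapping one halogen for another there left the number unchanged within the scatter. Taking the halogen away altogether is a larger change than that swap, and no measured pair tells what an unsubstituted ring does at this site. The expectation for this assay is therefore a modest move toward a higher number, by roughly a 3.3-fold higher number from compound 2 to compound 4 (0.51 log units; beyond the scatter), with a fair chance that it stays within the scatter.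

Compound 4 is estimated at 1.8 nM, with a range from 0.7 nM to 5 nM.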

Compound 4, inhibition constant: 8.32 nM
Compound 4: middle estimate off by 4.6-fold (0.66 log units), on the low side; the measured number lies above the stated range.
By their numbers in this assay, from the lowest: compounds 1 and 2 (each within the scatter of the next); then compound 3; then compound 4.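

Working notes: the halogen on this aromatic carbon matters far more than which halogen it is. In this assay the exchange of bromo for chloro gave only (a 1.1-fold higher number from compound 1 to compound 2 (0.05 log units; within the scatter)), while removing the halogen gave (a 15-fold higher number from compound 2 to compound 4 (1.18 log units; beyond the scatter)) with chloro as the group lost and (a 17-fold higher number from compound 1 to compound 4 (1.23 log units; beyond the scatter)) with bromo as the group lost. Both removals are large and point the same way, so among these compounds either halogen at this carbon keeps the number low, and hydrogen there costs more than the change of ring halogens on the other aromatic ring (a 2.0-fold higher number from compound 2 to compound 3 (0.31 log units; beyond the scatter)); no evidence on why this is so is available here.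

The compounds shown leave open whether the low number depends on a halogen as such, or whether a methyl, a methoxy or a nitrile on this aromatic carbon would hold it close to that of compound 2 (0.55 nM). They also leave open whether hydrogen in place of chloro would cost as much with the 2,4-difluorophenyl group of compound 3 (1.12 nM) in place of the 2,4-dichlorophenyl group.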